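A few compounds are considered here, and "the series" means these few. Any claim that something is new, unique, unknown or untested is made for them only; others in the source may bear on it.

Measured so far in an ADME assay on microsomes from liver (Homo sapiens) for metabolic stability, read by LC-MS, using NADPH, with a stated time of 30 min, tested at 1 uM; a lower number here means slower removal, a higher number faster removal of the compound:

compound 1 `COCc1ccc(-c2ccc3nnc(C(N)=O)c(N[C@@H](C)c4ccn(C)n4)c3c2)cn1` gives 14 mL.min-1.g-1
compound 2 `C[C@H](Nc1c(C(N)=O)nnc2ccc(-c3ccc(OCCCN4CCCC4)nc3)cc12)C1CCOCC1` gives 23 mL.min-1.g-1

Among these two numbers compound 2 stands at the higher end, with compound 1 the only neighbour, and the gap between them is within the usual scatter of this assay, so the two should be treated as alike rather than as ordered. Among the measured compounds shown here, no step between a pair of measured compounds that differ in one place is available, so nothing here directly shows what any single change does.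

Compound 3 `C[C@H](Nc1c(C(N)=O)nnc2ccc(-c3ccc(OCCCN4CCCC4)nc3)cc12)c1ccn(C)n1` differs from compound 2 in one place: 1-methyl-1H-pyrazol-3-yl in place of oxan-4-yl on a saturated chain carbon bound to a nitrogen on an aromatic ring and a saturated chain carbon. For the measured compounds named here, the same group that enters here is also the one carried by compound 1, whose value in this assay sits close to that of compound 2. On that basis the step from compound 2 to compound 3 is expected to be small, with no clear direction beyond the scatter, as a 1.3-fold lower number from compound 2 to compound 3 (0.11 log units; within the scatter). For compound 3 the estimate in this assay is 18 mL.min-1.g-1, with a likely range from 8 mL.min-1.g-1 to 38 mL.min-1.g-1.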

Compound 3, intrinsic clearance in microsomes in the Homo sapiens assay: 10 mL.min-1.g-1
Compound 3: the middle estimate sits 1.8-fold (0.26 log units) above what was measured, within the range that was stated.
By their numbers in the Homo sapiens assay, from the lowest: compounds 3, 1 and 2 (each within the scatter of the next, the first and the last beyond it).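

Among the compounds shown here, in the Homo sapiens assay, the one place that changes, on a saturated chain carbon bound to a nitrogen on an aromatic ring and a saturated chain carbon, now has a readable step: compound 2 gives 23 mL.min-1.g-1 and compound 3 gives 10 mL.min-1.g-1, and 1-methyl-1H-pyrazol-3-yl in place of oxan-4-yl gives a 2.3-fold lower number from compound 2 to compound 3 (0.36 log units; beyond the scatter), so the swap of this group does shift the number, if only modestly. In a physicochemical assay for lipophilicity, using the shake flask method, measured as octanol-water partition, with a stated time of 30 min, at pH 7.4 (a lower number here means a more polar compound, a higher number a more lipophilic compound), compound 2 gives 1.9 and compound 3 gives 1.8, and the same change gives a number 0.10 log units lower from compound 2 to compound 3 (within the scatter), so the two compounds read alike there even though they part in the Homo sapiens assay. The other change, 3-(pyrrolidin-1-yl)propoxy in place of methoxymethyl on an aromatic carbon, gives a 1.4-fold lower number from compound 1 to compound 3 (0.15 log units; within the scatter), so with 1-(1-methyl-1H-pyrazol-3-yl)ethyl held constant, compound 1 and compound 3 count as alike and this long chain shows no clear effect on the number.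

Nothing in the data gives a reason for the step at the chain carbon. Open too, on these data alone, is whether the step belongs to this particular ring or would also appear with another group at that place, such as a phenyl ring or a plain cyclohexyl ring, and whether it would hold with methoxymethyl on the aromatic carbon.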